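This account rests on a few compounds, and the source may have more. Where it says the series, first, only, none or still open, it means among the compounds named here.

Working notes on the series. In a functional assay on K562 cells (Homo sapiens) for inhibition, read by fluorescence, with a stated time of 72 h (a lower number here means a stronger inhibitor of growth, a higher number a weaker inhibitor of growth), compound 1 (`CCCCCCn1cnc2c(Nc3ccc(Cl)cc3)nc(N[C@H]3CC[C@H](N)CC3)nc21`) gives 2100 nM and compound 2 (`CCCCn1cnc2c(NCc3cccc(Cl)c3)nc(N[C@H]3CC[C@H](N)CC3)nc21`) gives 4300 nM while compound 3 (`CC(C)CCn1cnc2c(NCc3cccc(Cl)c3)nc(N[C@H]3CC[C@H](N)CC3)nc21`) gives 3100 nM as the starting point for the next step. Compound 3 lies between the other two numbers and within the scatter of each. The next entry is compound 4 (`CC(C)CCn1cnc2c(Nc3ccccc3)nc(N[C@H]3CC[C@H](N)CC3)nc21`). The change is phenyl in place of 3-chlorobenzyl on a nitrogen on an aromatic ring and it turns (3-chlorobenzyl)amino into anilino.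

Within the data shown here, only one measured step links two compounds that differ in one place, a 1.4-fold lower number from compound 2 to compound 3 (0.14 log units; within the scatter) and it concerns the saturated chain, not the group exchanged here. Among the measured compounds shown here, compound 1 also carries an aromatic ring on that nitrogen, but it differs from compound 3 in the chain as well, so no measured step isolates this exchange. The data therefore give no direction and no ground to expect a step beyond the scatter in this assay for this change. The estimated step is small (a 1.1-fold lower number from compound 3 to compound 4 (0.04 log units; within the scatter)) and remains uncertain. For compound 4 the expected value is 2800 nM with an estimated range from 1000 nM to 8000 nM in this read-out.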

Compound 4, concentration for 50% growth inhibition: 3500 nM
Compound 4: the middle estimate sits 1.3-fold (0.10 log units) below what was measured, and the stated range covers the measured number.
By their numbers in this assay, from the lowest: compounds 1, 3, 4 and 2 (each within the scatter of the next, the first and the last beyond it).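

Position notes: in this assay, the exchange of 3-chlorobenzyl for phenyl on the nitrogen gives a 1.1-fold higher number from compound 3 to compound 4 (0.05 log units; within the scatter) and is the first measured step at this position, since the earlier single-place step concerned only the saturated chain. With the rest of the structure held constant, this nitrogen therefore accepts anilino as well as (3-chlorobenzyl)amino, and this one pair shows no separation between the two groups in this read-out. The exchange removes both the chlorine and the benzyl carbon together, so the result cannot assign any share of the outcome to either, and no available measurement explains why the two compounds do not separate.

Unsubstituted benzyl on this nitrogen would separate the loss of the chlorine from the loss of the benzyl carbon, and that comparison remains open here. Also open is whether an amine or a carboxylic acid on the phenyl ring of compound 4 would give a step beyond the scatter, since the compounds shown carry neither group there.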